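The source may report more compounds than this note shows. Statements on the series, on what has been measured and on what is new or still open speak of the compounds shown alone.

The measured compounds:
Compound 1, `O=C1c2ccccc2N(Cc2ccccc2Cl)S(=O)(=O)N1Cc1ccccc1Cl`, in a functional assay on HEL cells (Homo sapiens); a higher number here means that more compound is tolerated, a lower number that less compound is tolerated: > 20000 nM, a limit of the assay rather than a number.
Compound 2, `O=S1(=O)N=C(OCc2ccccc2)c2ccccc2N1Cc1ccc(Cl)c(Cl)c1`, in this assay: 200000 nM.
Compound 3, `O=C(OCOCN1c2ccccc2C(=O)N(Cc2ccccc2)S1(=O)=O)c1ccccc1`, in this assay: 110000 nM.

Within the data shown here, only two of the three compounds give a number. Compound 3 sits at one end of those two, but the value of compound 2 lies within the usual scatter of repeated measurements, so no order between the two can be read. Compound 1 contributes only (the limit of > 20000 nM in this assay, at which 1 of the 3 values shown sits), and nothing more can be said of it.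

Compound 4, `C#CCOCN1c2ccccc2C(=O)N(Cc2ccccc2)S1(=O)=O`, has not yet been measured. It differs from compound 3 in a single place: ethynyl in place of benzoyloxy on a saturated chain carbon bound to an oxygen on a saturated carbon. Cut one bond further out, the same change reads (benzoyloxy)methyl to propargyl. Among the measured compounds shown here, no step between measured compounds shows what a change of this kind does in this assay, so the expectation rests on the two numbers alone. The step from compound 3 to compound 4 is expected to stay within the scatter, or close to it, as a 1.2-fold higher number from compound 3 to compound 4 (0.07 log units; within the scatter). Compound 4 is accordingly expected to give 130000 nM, with a range from 40000 nM to 400000 nM.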

Compound 4, minimum cytotoxic concentration: 140000 nM
Compound 4: the middle estimate sits 1.1-fold (0.03 log units) below what was measured; measured number inside the range.
By their numbers in this assay, from the lowest: compounds 3, 4 and 2 (each within the scatter of the next).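

Among these compounds, the step of a 1.3-fold higher number from compound 3 to compound 4 (0.10 log units; within the scatter) is the first that changes a single place, and it shows that in this assay ethynyl can stand in place of benzoyloxy on a saturated chain carbon bound to an oxygen on a saturated carbon with no change that can be read. Benzoyloxy brings 9 heavy atoms, including a six-membered aromatic ring of carbon only, while ethynyl brings 2 heavy atoms and no ring, yet compound 3 and compound 4 cannot be put in any order. Nothing measured here accounts for this result.

The compounds shown leave open whether an amine, a carboxylic acid or a longer chain at this place would also stay within the scatter of compound 3 in this assay, as this one step covers a single replacement. They also leave open whether the same change would read alike with the other groups carried by compound 1 and compound 2, whose structures differ from that of compound 3 in more than one place.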